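From Iodo to Amino on the Shared Core

The source may hold more compounds than are shown below. What is called first, only, known or untested is meant among the compounds shown, and "the series" means these compounds.

Three compounds share one core and differ only in the group on the six-membered carbon ring. In a functional assay on the whole organism for inhibition, with Nicotiana tabacum as the target (on this read-out lower numbers stand for stronger inhibition and higher numbers for weaker inhibition), compound 1 `Cc1nc(Nc2ccc(F)cc2)c2cc[nH]c2n1` gives 372000000 nM, compound 2 `Cc1nc(Nc2ccc(Br)cc2)c2cc[nH]c2n1` gives 170000000 nM, and compound 3 `Cc1nc(Nc2ccc(I)cc2)c2cc[nH]c2n1` gives 219000000 nM. Compound 3 stands with a 1.3-fold higher number from compound 2 to compound 3 (0.11 log units; within the scatter) and a 1.7-fold lower number from compound 1 to compound 3 (0.23 log units; within the scatter), so nothing separates it from either neighbour beyond the scatter; only a 2.2-fold lower number from compound 1 to compound 2 (0.34 log units; beyond the scatter) counts as a modest step. Compound 4 `Cc1nc(Nc2ccc(N)cc2)c2cc[nH]c2n1` brings (amino in place of iodo on an aromatic carbon). Among the measured compounds shown here, none of the measured steps exchanges a halogen for an amino group, so none speaks directly to this change, and the three halogen compounds lie close together. The estimate for compound 4 in this assay is therefore 300000000 nM, within 100000000 nM to 900000000 nM, meaning an expected 1.4-fold higher number from compound 3 to compound 4 (0.14 log units; within the scatter) that may well stay within the scatter in either direction.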

Compound 4, half-maximal inhibitory concentration: 195000000 nM
Beside the measured number, compound 4's estimate is 1.5-fold (0.19 log units) above it; the measured number falls inside the stated range.
By their numbers in this assay, from the lowest: compounds 2, 4, 3 and 1 (each within the scatter of the next, the first and the last beyond it).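

Amino is the first group here that is not a halogen, and it brings a hydrogen-bond donor and acceptor, yet its steps from the bromo and iodo compounds stay within the scatter (a 1.1-fold lower number from compound 3 to compound 4 (0.05 log units; within the scatter); a 1.1-fold higher number from compound 2 to compound 4 (0.06 log units; within the scatter)). The step from the fluoro compound also stays within the scatter (a 1.9-fold lower number from compound 1 to compound 4 (0.28 log units; within the scatter)), so all four groups on this aromatic carbon give closely similar numbers. Nothing measured here offers an explanation for this.

From the compounds shown here alone, whether a carboxylic acid, a methoxy group or a longer chain at this position would keep the number in the same narrow range remains open.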